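Phenyl in place of pyridin-4-yl: cytotoxicity working notes

This account rests on a few compounds, and the source may have more. Where it says the series, first, only, none or still open, it means among the compounds named here.

Values so far in a toxicity assay on NIH3T3 cells (Mus musculus) for cytotoxicity, read by resazurin assay (on this read-out lower numbers stand for an effect already at smaller amounts and higher numbers for an effect only at larger amounts of compound), are:

- compound 1 `c1ccc(-c2ccc(Cn3cncc3CNc3cccc(-c4ccccc4)c3)cc2)cc1` gives 10000 nM
- compound 2 `c1ccc(Cn2cncc2CNc2cccc(-c3ccncc3)c2)cc1` gives > 1000 nM

Compound 2 stands at > 1000 nM in this assay as a limit and not as a number. Among the measured compounds shown here, the data so far hold the limit of > 1000 nM in this assay, at which 1 of the 2 values shown sits, and no measured step between two compounds.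

Compound 3 `c1ccc(Cn2cncc2CNc2cccc(-c3ccccc3)c2)cc1` has not been measured. Its change from compound 2 is phenyl in place of pyridin-4-yl on an aromatic carbon, meta to a large group (phenyl in place of pyridin-4-yl on an aromatic carbon).

For the measured compounds named here, the only true number comes from compound 1 (10000 nM), and the expectation for this assay leans on it, with an effect only at larger amounts of compound. Read against the limit, the expected move is toward higher numbers, with an estimated step that the limit leaves unreadable from compound 2 to compound 3 as its size. Compound 2 has no number, so the real step may turn out smaller.

The estimate for compound 3 is 8000 nM with an expected range (2500 nM to 30000 nM).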

Compound 3, half-maximal effective concentration: > 750 nM
Compound 3 ended at the assay's limit; the forecaster's own chance of this, stated with the estimate: 35%; the middle value does not contradict the limit.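

Compound 3 gives > 750 nM in this assay, a limit and not a number. No step can be read between compound 3 and compound 2 or compound 1. The compounds shown leave open whether phenyl in place of pyridin-4-yl shifts the value in this assay at all, and in which direction.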